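Ethoxy in Place of Hydroxy: From Compound 3 to Compound 4

The source may report more compounds than this note shows. Statements on the series, on what has been measured and on what is new or still open speak of the compounds shown alone.

Of the compounds shown here, three sharing one core have been measured in a functional assay on MCF7 cells (Homo sapiens) for antiproliferative activity; on this read-out lower numbers stand for stronger inhibition of growth and higher numbers for weaker inhibition of growth. Compound 1 `COc1ccc(-c2nc3cc(F)ccc3s2)cc1C` gives 48 nM, compound 2 `COc1ccc(-c2nc3cc(F)ccc3s2)cc1Br` gives 850 nM, and compound 3 `COc1ccc(-c2nc3cc(F)ccc3s2)cc1O` gives 500 nM. On these numbers compound 3 stands second highest of the three: the step of a 10-fold higher number from compound 1 to compound 3 (1.02 log units; beyond the scatter) is large and beyond the scatter, whereas the step of a 1.7-fold lower number from compound 2 to compound 3 (0.23 log units; within the scatter) lies within the scatter, so compound 2 and compound 3 cannot be separated in this assay.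

Compound 4 `CCOc1cc(-c2nc3cc(F)ccc3s2)ccc1OC` has not yet been measured. It differs from compound 3 by ethyl in place of hydrogen on an oxygen on an aromatic ring. For the measured compounds named here, no measured step bears directly on this change: the steps of an 18-fold higher number from compound 1 to compound 2 (1.25 log units; beyond the scatter) and a 10-fold higher number from compound 1 to compound 3 (1.02 log units; beyond the scatter) both replace methyl on an aromatic carbon, and neither alters a group on the oxygen. What the data do show is that the hydroxy compound, compound 3, sits far from the methyl compound, compound 1, which gives 48 nM. With the hydroxy converted to ethoxy, compound 4 is expected to give roughly 250 nM, within a range of 50 nM to 1500 nM. The expected step of a 2.0-fold lower number from compound 3 to compound 4 (0.30 log units; within the scatter) is thus estimated as a moderate lowering of the number, with a real chance that it falls within the scatter.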

Compound 4, concentration for 50% growth inhibition: 80 nM
Compound 4: middle estimate off by 3.1-fold (0.49 log units), on the high side, within the range that was stated.
By their numbers in this assay, from the lowest: compounds 1 and 4 (each within the scatter of the next); then compounds 3 and 2 (each within the scatter of the next).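

In this assay, for the compounds shown here, ethyl in place of hydrogen on the oxygen gives a 6.3-fold lower number from compound 3 to compound 4 (0.80 log units; beyond the scatter) and so separates ethoxy from hydroxy, a result that the earlier compounds, with only a free hydroxy on this oxygen, could not show. Going by these compounds alone, the step of an 11-fold lower number from compound 2 to compound 4 (1.03 log units; beyond the scatter) also sets ethoxy apart from bromo, while a 1.7-fold higher number from compound 1 to compound 4 (0.22 log units; within the scatter) leaves ethoxy and methyl inseparable, so methyl is no longer the only group at this place that stands clear of both bromo and hydroxy. Nothing measured here accounts for the effect of the ethyl group on the read-out.

The compounds shown leave open whether this gain belongs to ethyl in particular or would also come with methoxy, propoxy or a longer chain on the same oxygen. They also leave open how an amine or a carboxylic acid in place of ethoxy would compare, and whether the ethyl step would keep its size with any change elsewhere on the shared core.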